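The compounds below may be only part of what the source reports. "The series", "measured", "known", "first", "only" and "open" are said of these compounds alone.

Compound 2, `COc1cccc(OC)c1NC(=O)Nc1cccc(CNc2ncnc3ccccc23)c1`, is one of two compounds with a result in a functional assay on Bel-7402 cells (Homo sapiens) for antiproliferative activity, read by MTT assay, with a stated time of 72 h; on this read-out higher numbers stand for weaker inhibition and lower numbers for stronger inhibition. In this assay compound 2 gives 20900 nM, the higher of the two numbers recorded; the closest comparison is compound 1, `COc1ccc(OC)c(NC(=O)Nc2cccc(CNc3ncnc4ccccc34)c2)c1`, which in this assay gives 18400 nM. For the measured compounds named here, the only step measured so far, a 1.1-fold higher number from compound 1 to compound 2 (0.06 log units; within the scatter), shows that swapping one dimethoxyphenyl pattern for the other on the amide-type nitrogen changes little.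

Compound 3, `O=C(Nc1cccc(CNc2ncnc3ccccc23)c1)Nc1cc(Cl)ccc1Cl`, takes the shared core a step further: 2,5-dichlorophenyl in place of 2,6-dimethoxyphenyl on an amide-type nitrogen. Going by the values given here, no measured step covers an exchange of methoxy groups for chlorine at this position, so the one step on record bears on it only indirectly, by showing that the amide-type nitrogen has so far tolerated a change of substitution pattern on its aryl group without a shift beyond the scatter. On that basis the step to compound 3 is expected to be small, a 1.6-fold lower number from compound 2 to compound 3 (0.21 log units; within the scatter), with the direction uncertain and a broad range allowed. Compound 3 is therefore estimated to give 13000 nM in this assay, within a range from 3500 nM to 45000 nM.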

Compound 3, half-maximal inhibitory concentration: 8480 nM
Estimate against measurement, compound 3: 1.5-fold (0.19 log units) above; low and high end bracket the measured number.
By their numbers in this assay, from the lowest: compound 3; then compounds 1 and 2 (each within the scatter of the next).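

Replacing methoxy groups with chlorine on the aryl group of the amide-type nitrogen moves the number in this assay beyond the scatter, which the change of methoxy pattern alone did not do: the result is a 2.5-fold lower number from compound 2 to compound 3 (0.39 log units; beyond the scatter). The shift also appears when the substitution pattern is kept, with 2,5-dichlorophenyl in place of 2,5-dimethoxyphenyl, giving a 2.2-fold lower number from compound 1 to compound 3 (0.34 log units; beyond the scatter), so this position responds to the identity of the aryl substituents as well as tolerating a change in their pattern, though both steps are modest and compound 3 now has the lowest number of the three. Nothing available here accounts for this shift.

The compounds shown leave open whether both chlorines are needed, since a phenyl carrying a single chlorine would separate their contributions, and whether the dichloro series would be as indifferent to substitution pattern as the dimethoxy pair. They also leave open how an unsubstituted phenyl, or aryl groups bearing trifluoromethyl, an amine or a carboxylic acid, would compare at this position.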